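Swapping a Methoxyphenyl for a Hydroxyphenyl

The source may report more compounds than this note shows. Statements on the series, on what has been measured and on what is new or still open speak of the compounds shown alone.

Of the compounds shown here, three sharing one core have been tested in a functional assay on MDA-MB-231 cells (Homo sapiens) for antiproliferative activity, read by MTT assay, with a stated time of 48 h; a higher number here means a weaker inhibitor, a lower number a stronger inhibitor. Compound 1 `C/C(=C\CC/C(C)=C/CC[C@@H]1[C@@]2(C)CCC(=O)C(C)(C)[C@H]2CC[C@@]1(C)O)CC/C=C(\C)C(=O)OCc1cn(C[C@@H]2O[C@H](n3ccc(=O)[nH]c3=O)C[C@H]2O)nn1` gives 26300 nM. Compound 2 `COc1ccc(-n2cc(COC(=O)/C(C)=C/CC/C(C)=C/CC/C(C)=C/CC[C@@H]3[C@@]4(C)CCC(=O)C(C)(C)[C@H]4CC[C@@]3(C)O)nn2)cc1` gives > 150000 nM, which is a limit of the assay and not a number. Compound 3 `C/C(=C\CC/C(C)=C/CC[C@@H]1[C@@]2(C)CCC(=O)C(C)(C)[C@H]2CC[C@@]1(C)O)CC/C=C(\C)C(=O)OCc1cn(C[C@@H]2O[C@H](n3ccc(=O)[nH]c3=O)[C@H]3OC(C)(C)O[C@H]32)nn1` gives > 150000 nM, which is also a limit. Compound 2 therefore stands at the limit of > 150000 nM in this assay, at which 2 of the 3 values shown sit.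

The next compound to be measured is compound 4 `C/C(=C\CC/C(C)=C/CC[C@@H]1[C@@]2(C)CCC(=O)C(C)(C)[C@H]2CC[C@@]1(C)O)CC/C=C(\C)C(=O)OCc1cn(-c2cccc(O)c2)nn1`. Its change from compound 2 is 3-hydroxyphenyl in place of 4-methoxyphenyl on an aromatic nitrogen; in words, 3-hydroxyphenyl in place of 4-methoxyphenyl on an aromatic nitrogen. No measured pair among these compounds isolates this kind of swap, so the size of the step can only be expected. Compound 1 gives 26300 nM, which shows that a measurable number is possible with this core, so a modest move towards stronger inhibition in this assay is expected. The expected step is an at least 2.1-fold lower number from compound 2 to compound 4 (0.33 log units; beyond the scatter). Compound 4 is estimated at 70000 nM, with an expected range from 20000 nM to 170000 nM.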

Compound 4, half-maximal inhibitory concentration: 139000 nM
Estimate against measurement, compound 4: 2.0-fold (0.30 log units) below, and the stated range covers the measured number.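

In this assay, compound 4 gives 139000 nM, a true number and not a limit, so a substituted phenyl ring on this aromatic nitrogen can give a measurable result with the shared core. The change to 3-hydroxyphenyl reads as an at least 1.0-fold lower number from compound 2 to compound 4 (0.03 log units; that floor lies within the scatter), which means that only a floor for the step is known, and this floor does not establish a real gain in strength. The step remains a floor because compound 2 has no exact value: the limit of > 150000 nM in this assay, at which 2 of the 4 values shown sit.

This single swap replaces methoxy with hydroxy and also moves the group around the phenyl ring, so the compounds shown cannot separate those two changes. Going by these compounds, it also remains open whether an amine or a carboxylic acid on that phenyl ring would bring the number closer to that of compound 1, which gives 26300 nM.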